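Turning the double bond of compound 2

The source may report more compounds than this note shows. Statements on the series, on what has been measured and on what is new or still open speak of the compounds shown alone.

Measured in a functional assay on cells (Endothelial cell, Bos taurus) for antiproliferative activity; on this read-out lower numbers stand for stronger inhibition and higher numbers for weaker inhibition:
- Compound 1 `COc1cc(/C(F)=C/c2cc(O)c3ccsc3c2)cc(OC)c1OC` gives 390 nM
- Compound 2 `COc1cc(/C=C/c2cc(O)c3ccsc3c2)cc(OC)c1OC` gives 38000 nM

Compound 2 has the higher of the two numbers. In this series, compound 2 at 38000 nM is the weaker inhibitor, and its gap to compound 1 lies well beyond the scatter of repeated measurements. The next compound to be tested is compound 3 `COc1cc(/C=C\c2cc(O)c3ccsc3c2)cc(OC)c1OC`, an isomer of compound 2. The change is the two compounds have the same atoms and bonds and differ only in configuration as drawn: 1 of 1 stereo elements differ; a double bond is drawn E in compound 2 and Z in compound 3 and nothing else: no atom or bond leaves or enters, and only the double bond is redrawn from E to Z.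

Going by the values given here, no measured pair in this small set isolates such a change, so the expectation rests on limited evidence. Compound 1 at 390 nM shows that a much lower number is reachable in this assay with a closely related structure. A large step towards stronger inhibition, well beyond the scatter, is expected, and the estimated size is a 760-fold lower number from compound 2 to compound 3 (2.88 log units; beyond the scatter) on this read-out. For compound 3 the estimated value is 50 nM in this assay, with an expected range from 5 nM to 1000 nM as its bounds.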

Compound 3, half-maximal inhibitory concentration: 87 nM
Beside the measured number, compound 3's estimate is 1.7-fold (0.24 log units) below it; the range from low to high includes it.
By their numbers in this assay, from the lowest: compound 3; then compound 1; then compound 2.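

In this assay, redrawing the double bond from E to Z gives a 440-fold lower number from compound 2 to compound 3 (2.64 log units; beyond the scatter), a large step. The earlier compounds shown here held no pair that isolated this change, so they could not show that the configuration at this one double bond matters on this read-out, and matters this much, with the substituents on the shared core left untouched. The step can be assigned to the configuration alone, with no atom leaving or entering, because of a plain structural fact: the fact that compounds 2 and 3 differ only in the configuration as drawn.

The compounds shown leave open whether the Z configuration keeps its advantage when the rest of the structure changes, for instance when the hydroxyl on the shared core gives way to an amine or a carboxylic acid. They also give no account of why the two isomers stand so far apart, for the only thing reported for them is their numbers in this assay, and these say nothing about the mechanism behind the gap.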